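Chalcone-Type Pyrazoles: Swapping the Aryl Ketone Ring

The compounds below may be only part of what the source reports. "The series", "measured", "known", "first", "only" and "open" are said of these compounds alone.

The shared core carries a trimethoxyphenyl group and an enone arm ending in a second aryl ring. Compound 1 `COc1ccc(C(=O)/C=C/c2cc(-c3cc(OC)c(OC)c(OC)c3)n[nH]2)cc1OC` bears a 3,4-dimethoxyphenyl ring on the carbonyl carbon, and in a functional assay on SNB-19 cells (Homo sapiens) for cytotoxicity, read by sulforhodamine B assay, with a stated time of 48 h, tested at 100 uM (on this read-out lower numbers stand for a stronger effect and higher numbers for a weaker effect at the one concentration tested), compound 1 gives -95%. Within the data shown here, compound 2 `COc1ccc(C(=O)/C=C/c2cc(-c3cc(OC)c(OC)c(OC)c3)n[nH]2)cc1` keeps only one methoxy group on that ring, and in this assay compound 2 gives -6%. Among the measured compounds shown here, of the two numbers known, compound 2 is the higher one; its nearest neighbour is compound 1, and the step of a number 89 percentage points higher from compound 1 to compound 2 (beyond the scatter) lies beyond the scatter.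

Compound 3 `COc1cc(-c2cc(/C=C/C(=O)c3ccc(F)c(F)c3)[nH]n2)cc(OC)c1OC` differs from compound 2 in one place: 3,4-difluorophenyl in place of 4-methoxyphenyl on a carbonyl carbon. For the measured compounds named here, no measured step covers this exchange; the only step at hand, from compound 1 to compound 2, shows that the ring on the carbonyl carbon matters a great deal, since removing a methoxy there raised the number sharply. Because compound 2 already gives -6%, the expected step of a number 6 percentage points higher from compound 2 to compound 3 (within the scatter) is estimated to be small, with no clear direction. Compound 3 is therefore expected to give about 0%, within -40% to 30%.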

Compound 3, a percentage reported as activity, at one concentration (the size of the read-out at that concentration, not a potency): 22%
For compound 3 the middle estimate is 22 percentage points below the measured one, within the range that was stated.
By their numbers in this assay, from the lowest: compound 1; then compound 2; then compound 3.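

In this assay, among these compounds, the exchange of 4-methoxyphenyl for 3,4-difluorophenyl on a carbonyl carbon gives a number 28 percentage points higher from compound 2 to compound 3 (beyond the scatter) and the exchange of 3,4-dimethoxyphenyl for the same ring gives a number 117 percentage points higher from compound 1 to compound 3 (beyond the scatter) so this position still moves the number once a ring has only one methoxy group left to lose. Across these three compounds the number rises as methoxy groups leave this ring, and none of the three goes against that order, but compound 3 also brings in fluorine, so the loss of the last methoxy group and the arrival of fluorine cannot be told apart. Nothing is available here that explains why the 3,4-difluorophenyl ring gives the highest number of the three.

The compounds shown leave open where a plain phenyl ring, a phenyl ring with a single fluorine or a phenyl ring carrying an amine would fall in this order on the carbonyl carbon. They also leave open whether the same order would hold if the trimethoxyphenyl group were exchanged or the enone arm gave way to a longer chain.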